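Phenyl for chloropyridinyl at the ether-bearing carbon

The compounds below may be only part of what the source reports. "The series", "measured", "known", "first", "only" and "open" are said of these compounds alone.

Measured so far:
compound 1 `Cc1cc(C(=O)O)ccc1CN1CCC[C@H](O[C@H](CO)c2cc(Cl)cc(Cl)c2)[C@@H]1c1ccc(F)cc1` — "nd" (no result reported)
compound 2 `Cc1cc(C(=O)O)ccc1CN1CCC[C@H](O[C@H](CO)c2ccnc(Cl)c2)[C@@H]1c1ccccc1` — > 200000 nM
compound 3 `Cc1cc(C(=O)O)ccc1CN1CCC[C@H](OC(c2cc(Cl)cc(Cl)c2)C(C)(C)O)[C@@H]1c1ccccc1` — 121000 nM

In an assay on isolated protein for activation of cGMP-dependent protein kinase 1 (Homo sapiens), read by ADP-Glo, with stated times of 30 min and 2 h (on this read-out lower numbers stand for an effect already at smaller amounts and higher numbers for an effect only at larger amounts of compound), compound 2 reaches only the limit of the assay, > 200000 nM, and no number is reported. Among the compounds shown, compound 2 thus stands at a limit. Compound 1 has no result at all, "nd" (no result reported). Only compound 3 carries a single number, 121000 nM. Within the data shown here, no step between two measured compounds can be drawn from these values.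

Compound 4 `Cc1cc(C(=O)O)ccc1CN1CCC[C@H](O[C@H](CO)c2ccccc2)[C@@H]1c1ccccc1` differs from compound 2 in one place: phenyl in place of 2-chloropyridin-4-yl on a saturated chain carbon bound to an oxygen on a saturated carbon and a saturated chain carbon. Among the measured compounds shown here, since the data give no measured step and compound 2 sits at a limit, any shift is expected to be small, most likely within the scatter, with a slight gain possible; the estimated step is an at least 1.3-fold lower number from compound 2 to compound 4 (0.12 log units; that floor lies within the scatter). Compound 4 is therefore expected at about 150000 nM, within 50000 nM to 400000 nM.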

Compound 4, half-maximal effective concentration: > 200000 nM
Compound 4 ended at the assay's limit; the forecaster's own chance of this, stated with the estimate: 50%; middle value at least 1.3-fold (0.12 log units) from the limit.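

Among these compounds, compound 2 and compound 4 both stand at a limit in this assay, and no step between them can be read. From the compounds shown here alone, whether phenyl and 2-chloropyridin-4-yl differ at all at this place remains open.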